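The source may hold more compounds than are shown below. What is called first, only, known or untested is meant among the compounds shown, and "the series" means these compounds.

Going by the values given here, compound 3 `O=C1O[C@@H](Cn2ccnc2)CN1c1ccc(-n2cc(-c3ccccn3)cn2)c(F)c1` carries the only number in the set: in an ADME assay on L02 cells (Homo sapiens) for cytotoxicity, read by MTT assay, with a stated time of 48 h (a higher number here means a weaker inhibitor, a lower number a stronger inhibitor), compound 3 gives 350 ug/mL. Compound 1 `COC(=O)CC1CCN(C[C@H]2CN(c3ccc(-n4cc(-c5ccccn5)cn4)c(F)c3)C(=O)O2)CC1` gives > 400 ug/mL, a limit of the assay rather than a number. Compound 2 `O=C(OC[C@H]1CN(c2ccc(-n3cc(-c4ccccn4)cn3)c(F)c2)C(=O)O1)c1ccccc1` likewise gives > 400 ug/mL, again a limit. The set is bounded by the limit of > 400 ug/mL in this assay, at which 2 of the 3 values shown sit. Compound 4 `O=CNC[C@H]1CN(c2ccc(-n3cc(-c4ccccn4)cn3)c(F)c2)C(=O)O1` differs from compound 3 by formylamino in place of 1H-imidazol-1-yl on a saturated chain carbon bound to a saturated ring carbon. The measured steps that bear on this exchange change a group at the same place: an at least 1.1-fold lower number from compound 1 to compound 3 (0.05 log units; that floor lies within the scatter) and an at least 1.1-fold lower number from compound 2 to compound 3 (0.05 log units; that floor lies within the scatter); both read only as floors lying within the scatter. On that basis no step beyond the scatter is expected for a 1.1-fold higher number from compound 3 to compound 4 (0.04 log units; within the scatter). Compound 4 is therefore expected to give 380 ug/mL, between 250 ug/mL and 600 ug/mL, with a fair chance that only a limit is reported.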

Compound 4, half-maximal inhibitory concentration: > 400 ug/mL
Compound 4: no number, only a limit (the forecaster's own chance of this, stated with the estimate: 50%); middle value at least 1.0-fold (0.02 log units) from the limit.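

At this place in this assay, formylamino in place of 1H-imidazol-1-yl gives an at least 1.1-fold higher number from compound 3 to compound 4 (0.05 log units; that floor lies within the scatter). The steps to compound 4 from compound 1 and from compound 2 cannot be read, as both ends of each are limits. A group with no ring now sits at the same limit as the ring-bearing groups of compound 1 and compound 2, with compound 3 the only exception: the limit of > 400 ug/mL in this assay, at which 3 of the 4 values shown sit.

From the compounds shown here alone, how far compound 1, compound 2 and compound 4 lie past that limit stays open. So does whether a primary amine or a carboxylic acid on the same chain carbon would give a number beyond the scatter from compound 3.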